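The source may report more compounds than this note shows. Statements on the series, on what has been measured and on what is new or still open speak of the compounds shown alone.

Measured compounds:
compound 1 `CCCCCNC(=O)/C=C/c1ccccc1` – 76% in a functional assay on the whole organism for inhibition, with Brassica rapa subsp. chinensis as the target, with a stated time of 3 days, tested at 100 ppm; on this read-out lower numbers stand for less inhibition of growth and higher numbers for more inhibition of growth at the one concentration tested
compound 2 `CCCCCCCCCCCCNC(=O)/C=C/c1ccccc1` – 32% in this assay
compound 3 `CCCCCCCCNC(=O)/C=C/c1ccccc1` – 42% in this assay

Compound 3 stands second highest of the three numbers in this assay; compound 2 lies within the scatter of it, while compound 1 lies well above it. Compound 4 `CCCCCCNC(=O)/C=C/c1ccccc1` differs from compound 3 by hydrogen in place of ethyl on a saturated chain carbon, six bonds along the chain from an amide-type nitrogen. The bearing steps are chain changes on the same core: a number 34 percentage points lower from compound 1 to compound 3 (beyond the scatter) and a number 44 percentage points lower from compound 1 to compound 2 (beyond the scatter), both large and both with longer chains giving lower inhibition, whereas a number 10 percentage points higher from compound 2 to compound 3 (within the scatter) stayed within the scatter. Shortening the chain of compound 3 is therefore expected to raise inhibition in this assay, though by less than the full step seen from compound 1, because a number 34 percentage points lower from compound 1 to compound 3 (beyond the scatter) spanned a larger change. Compound 4 is expected at 60%, between 45% and 76%. The expected step is a number 18 percentage points higher from compound 3 to compound 4 (beyond the scatter).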

Compound 4, percent growth inhibition at one concentration: 82%
For compound 4 the middle estimate is 22 percentage points below the measured one, outside the stated range (above it).
By their numbers in this assay, from the lowest: compounds 2 and 3 (each within the scatter of the next); then compounds 1 and 4 (each within the scatter of the next).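

In this assay the change at six bonds along the chain from an amide-type nitrogen carries a large effect: hydrogen in place of ethyl gives a number 40 percentage points higher from compound 3 to compound 4 (beyond the scatter) and hydrogen in place of hexyl gives a number 50 percentage points higher from compound 2 to compound 4 (beyond the scatter) at the same place. Methyl in place of hydrogen at five bonds along the chain gives a number 6 percentage points higher from compound 1 to compound 4 (within the scatter) and so stays within the scatter, which places the large loss beyond the chain of compound 4. Nothing measured here bears on the cause of this step. On these data alone, a heptyl chain, a butyl chain and a chain ending in an amine on the shared core remain open.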